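The source may report more compounds than this note shows. Statements on the series, on what has been measured and on what is new or still open speak of the compounds shown alone.

The measured compounds, each with its result in a functional assay on MCF7 cells (Homo sapiens) for antiproliferative activity, read by MTT assay, with a stated time of 48 h; on this read-out lower numbers stand for stronger inhibition and higher numbers for weaker inhibition:

Compound 1, `CCNCC(=O)Nc1cc(OC)ccc1C(=O)c1ccc2c(c1)C=CC(C)(C)O2`: 6310 nM
Compound 2, `COc1ccc(C(=O)c2ccc3c(c2)C=CC(C)(C)O3)c(NC(=O)CN(C)C)c1`: 3560 nM
Compound 3, `C=C(c1ccc(OC)cc1NC(=O)CNCC)c1ccc(OC)c2c1C=CC(C)(C)O2`: 2920 nM

Compounds 1 and 2 share one core and differ in a single place: dimethylamino in place of ethylamino on a saturated chain carbon bound to a carbonyl carbon. In this assay this change gave a 1.8-fold lower number from compound 1 to compound 2 (0.25 log units; within the scatter), a step that the stated scatter of the measurement fully covers, so the two compounds cannot be told apart on this read-out.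

Compound 3 rests on a different core; how its core differs from that of compound 1 is not broken down here. In this assay compound 3 and compound 2 give numbers within the scatter of each other, while compound 1 gives a number that lies beyond the scatter from that of compound 3.

Compound 4, `C=C(c1ccc(OC)cc1NC(=O)CN(C)C)c1ccc(OC)c2c1C=CC(C)(C)O2`, is the not yet measured partner of compound 3. It differs from compound 3 in exactly the way compound 2 differs from compound 1: dimethylamino in place of ethylamino on a saturated chain carbon bound to a carbonyl carbon. The place of the change reads the same in both pairs, so this is the same change carried onto the second core.

Among the compounds with values here, because the first instance of this change gave only a 1.8-fold lower number from compound 1 to compound 2 (0.25 log units; within the scatter), compound 4 is expected to land close to compound 3, with a step of about a 1.5-fold lower number from compound 3 to compound 4 (0.16 log units; within the scatter). Compound 4 is therefore estimated at 2000 nM in this assay, with a plausible range from 900 nM to 4500 nM, and the expectation rests on a single prior pair, so it is held loosely.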

Compound 4, half-maximal inhibitory concentration: 2580 nM
For compound 4 the middle estimate is 1.3-fold (0.11 log units) below the measured one; the range from low to high includes it.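

In this assay, putting dimethylamino in place of ethylamino on the second core gave a 1.1-fold lower number from compound 3 to compound 4 (0.05 log units; within the scatter), so on this core too the change stays inside what repeated measurements would scatter by. Set beside the first instance, the change reads alike on the two cores: the same change on two cores in this assay, a 1.8-fold lower number (0.25 log units; within the scatter) from compound 1 to compound 2 and a 1.1-fold lower number (0.05 log units; within the scatter) from compound 3 to compound 4, 1.6-fold (0.19 log units) apart, within the scatter of two such steps This shows that, in these two pairs, the exchange carries from one core to the other without any step that can be told from scatter, but it does not show that the change is without effect, since small real shifts could lie hidden within that scatter, and two pairs cannot establish a rule for the wider series.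

The compounds shown carry only ethylamino and dimethylamino at this place, so it remains open how the number would respond to a cyclic amine such as morpholine or pyrrolidine, to an unsubstituted amino group, or to a longer chain carrying the amine. Also open, from the compounds shown here alone, is whether the exchange would read the same way on any core other than these two.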